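From Methyl to Chloro: Expected Growth Inhibition of Compound 3

This account rests on a few compounds, and the source may have more. Where it says the series, first, only, none or still open, it means among the compounds named here.

Compound 1, `N#C[Se]c1ccc(NC(=O)Oc2ccc(F)cc2)cc1`: in a functional assay on HT-29 cells (Homo sapiens) for cytotoxicity, read by MTT assay, with a stated time of 72 h (a lower number here means a stronger inhibitor of growth, a higher number a weaker inhibitor of growth), compound 1 gives 8800 nM.
Compound 2, `Cc1ccc(OC(=O)Nc2ccc([Se]C#N)cc2)cc1`: in this assay compound 2 gives 8800 nM.

Compound 2 stands level with compound 1 on these numbers; the step from one to the other, no change at the digits printed from compound 1 to compound 2 (within the scatter), lies within the scatter. Compound 3 is `N#C[Se]c1ccc(NC(=O)Oc2ccc(Cl)cc2)cc1`, and it differs from compound 2 by chloro in place of methyl on an aromatic carbon. Among the measured compounds shown here, the only measured step that bears on this change is no change at the digits printed from compound 1 to compound 2 (within the scatter), in which one small group replaced another on the same aromatic carbon without any movement beyond the scatter. The exchange of methyl for chloro is again a one-for-one swap of single heavy atoms at that carbon, so nothing in the measured pair suggests a shift in this assay in either direction. Compound 3 is therefore expected to show a step of no change at the digits printed from compound 2 to compound 3 (within the scatter), no more than the scatter. Compound 3 is estimated at 8800 nM, with a range from 4000 nM to 19000 nM.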

Compound 3, concentration for 50% growth inhibition: 11800 nM
Compound 3: middle estimate off by 1.3-fold (0.13 log units), on the low side, within the range that was stated.
By their numbers in this assay, from the lowest: compounds 1, 2 and 3 (each within the scatter of the next).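

Read in this assay the aromatic carbon para to a large group now carries fluoro, methyl or chloro, and chloro in place of methyl gives a 1.3-fold higher number from compound 2 to compound 3 (0.13 log units; within the scatter) while chloro in place of fluoro gives a 1.3-fold higher number from compound 1 to compound 3 (0.13 log units; within the scatter) with the rest of the structure unchanged. The earlier pair covered only fluoro and methyl, whereas this result adds a chlorine at the same carbon and all three compounds remain within the scatter of one another. Nothing available bears on why these three groups read alike.

The compounds shown leave open whether a group of another kind at this carbon, such as an amine, a carboxylic acid or a longer chain, would also stay within the scatter. They also leave open whether these swaps would read alike in other cell lines.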